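The compounds below may be only part of what the source reports. "The series", "measured", "known", "first", "only" and "open" are said of these compounds alone.

Values in an ADME assay on L6 cells (Rattus norvegicus) for inhibition, read by resazurin assay, with a stated time of 72 h; a higher number here means a weaker inhibitor, a lower number a stronger inhibitor:
- compound 1 `CC(=O)O[C@@H]1[C@H](OC(C)=O)[C@@H](C[S+](C)[O-])O[C@H]1n1cnc2c(N)nc(Cl)nc21`: 168000 nM
- compound 2 `CC(=O)O[C@@H]1[C@H](OC(C)=O)[C@@H](CI)O[C@H]1n1cnc2c(N)nc(F)nc21`: 6300 nM

Compound 2 holds the lower of these two numbers, so it is the stronger inhibitor of the pair, and the gap to compound 1 lies beyond the scatter. The next compound to be read in this assay is compound 3 `CC(=O)O[C@@H]1[C@H](OC(C)=O)[C@@H](CI)O[C@H]1n1cnc2c(N)nc(Cl)nc21`. It differs from compound 2 in one place: chloro in place of fluoro on an aromatic carbon. This change sits between two ring nitrogen atoms. Among the compounds with values here, the two measured compounds differ in more than this one place, so no measured step shows what such a swap does. A small rise in the number is the cautious expectation, perhaps no larger than the scatter. The expected change is a 1.6-fold higher number from compound 2 to compound 3 (0.20 log units; within the scatter). Compound 3 is estimated at 10000 nM, with an expected range from 3000 nM to 40000 nM.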

Compound 3, half-maximal inhibitory concentration: 86000 nM
Estimate against measurement, compound 3: 8.6-fold (0.93 log units) below, and the stated range ends below it.
By their numbers in this assay, from the lowest: compound 2; then compounds 3 and 1 (each within the scatter of the next).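

In this assay the change of fluoro to chloro on the aromatic carbon between two ring nitrogen atoms gives a 14-fold higher number from compound 2 to compound 3 (1.14 log units; beyond the scatter) and so shows that this single atom matters greatly in this series. The other single change, one iodine atom in place of a group of 3 heavy atoms on the saturated chain carbon, gives a 2.0-fold lower number from compound 1 to compound 3 (0.29 log units; within the scatter) and does not separate the two compounds when chloro occupies the aromatic position. Nothing available explains why the halogen swap has so large an effect.

The compounds shown leave open how bromo, an amine or a methoxy group would read on this aromatic carbon. They also leave open whether the group of 3 heavy atoms and iodine would still read alike with fluoro on that carbon.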